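Adding a second fluorine to compound 3

A few compounds are considered here, and "the series" means these few. Any claim that something is new, unique, unknown or untested is made for them only; others in the source may bear on it.

Measured so far:
compound 1, `O=C1OC[C@H](Cc2cccc(F)c2)[C@H]1Cc1ccc(Cl)c(Cl)c1`, gives 14000 nM in a functional assay on HL-60 cells (Homo sapiens) for cytotoxicity, read by WST assay, with a stated time of 48 h; a lower number here means that less compound is needed, a higher number that more compound is needed for the effect;
compound 2, `O=C1OC[C@H](Cc2ccc(F)c(F)c2)[C@H]1Cc1ccc(Cl)c(Cl)c1`, gives 25000 nM;
compound 3, `Fc1ccc(C[C@H]2COC[C@@H]2Cc2ccc(Cl)c(Cl)c2)cc1`, gives 43000 nM.

Compound 1 and compound 2 share one core, while compound 3 is built on another; the difference between the two cores is not broken down here. Compound 3 needs a higher concentration than compound 1, whereas against compound 2 it stands within the usual scatter.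

Within the first pair, the change fluoro in place of hydrogen on an aromatic carbon produced a 1.8-fold higher number from compound 1 to compound 2 (0.25 log units; within the scatter).

Compound 4, `Fc1ccc(C[C@H]2COC[C@@H]2Cc2ccc(Cl)c(Cl)c2)cc1F`, is not yet measured. It differs from compound 3 by fluoro in place of hydrogen on an aromatic carbon. This is the same kind of change as from compound 1 to compound 2, though not identical in its setting: in compound 2 the entering fluoro is para to a large group, in compound 4 it is meta to a large group.

Because a 1.8-fold higher number from compound 1 to compound 2 (0.25 log units; within the scatter) stayed within the scatter, a comparably small step is expected here, namely a 1.4-fold higher number from compound 3 to compound 4 (0.14 log units; within the scatter). Compound 4 is therefore estimated at 60000 nM, plausibly between 25000 nM and 140000 nM.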

Compound 4, half-maximal effective concentration: 18000 nM
Compound 4: middle estimate off by 3.3-fold (0.52 log units), on the high side; measured number below the stated range.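

In this assay, fluoro in place of hydrogen on an aromatic carbon gave a 2.4-fold lower number from compound 3 to compound 4 (0.38 log units; beyond the scatter), a modest step that runs opposite in direction to the one seen on the first core. Set side by side, the two steps do not match, so in this series the outcome of this change cannot simply be carried from one core to the other: the same change on two cores in this assay, a 1.8-fold higher number (0.25 log units; within the scatter) from compound 1 to compound 2 and a 2.4-fold lower number (0.38 log units; beyond the scatter) from compound 3 to compound 4, 4.3-fold (0.63 log units) apart, beyond the scatter of two such steps This does not show why the steps differ, since each core offers only one pair and the setting of the entering fluoro on the ring also differs between the pairs, leaving the core and that setting unseparated.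

The compounds shown carry only fluoro on this ring, so it stays open whether a methoxy group, a nitrile or an amine in the same place would also behave differently on the two cores. On these data alone, it also stays open whether a second pair on each core would repeat this split or remove it.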